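The compounds below may be only part of what the source reports. "The series", "measured", "known", "first", "only" and "open" are said of these compounds alone.

Compound 3 `Cn1ccc2c(Oc3ccc(NC(=O)c4nn(-c5ccc(Br)cc5)ccc4=O)cc3)ccnc21` gives 59400 nM in a functional assay on A549 cells (Homo sapiens) for cytotoxicity, read by MTT assay, with a stated time of 72 h (a higher number here means a weaker inhibitor, a lower number a stronger inhibitor), the highest number among the three measured compounds. Compound 1 `O=C(Nc1ccc(Oc2ccnc3[nH]ccc23)cc1)c1nn(-c2ccc(Br)cc2)ccc1=O` gives 6240 nM, and compound 2 `O=C(Nc1ccc(Oc2ccnc3[nH]ccc23)cc1)c1nn(-c2ccccc2)ccc1=O` gives 10500 nM. The step of a 9.5-fold higher number from compound 1 to compound 3 (0.98 log units; beyond the scatter) came from methyl in place of hydrogen on an aromatic nitrogen and lay beyond the scatter. Compound 4 `Cn1ccc2c(Oc3ccc(NC(=O)c4nn(-c5ccc(Cl)c(C(F)(F)F)c5)ccc4=O)cc3)ccnc21` differs from compound 3 by 4-chloro-3-(trifluoromethyl)phenyl in place of 4-bromophenyl on an aromatic nitrogen. Among the measured compounds shown here, the only measured step that touches the same aryl group is a 1.7-fold higher number from compound 1 to compound 2 (0.23 log units; within the scatter), hydrogen in place of bromo on an aromatic carbon, which stayed within the scatter. On that basis a step of a 1.5-fold lower number from compound 3 to compound 4 (0.17 log units; within the scatter) is expected for compound 4, with no change beyond the scatter anticipated. Compound 4 is therefore estimated at 40000 nM, in the range 12000 nM to 130000 nM.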

Compound 4, half-maximal inhibitory concentration: 11400 nM
Compound 4: the middle estimate sits 3.5-fold (0.55 log units) above what was measured; the measured number lies below the stated range.
By their numbers in this assay, from the lowest: compounds 1, 2 and 4 (each within the scatter of the next); then compound 3.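

In this assay, the aryl group on the aromatic nitrogen proved able to shift the number beyond the scatter: 4-chloro-3-(trifluoromethyl)phenyl in place of 4-bromophenyl gave a 5.2-fold lower number from compound 3 to compound 4 (0.72 log units; beyond the scatter) on the methylated core, whereas the earlier change on this aryl group had stayed within the scatter. So this position is not indifferent to its substituents. No evidence here bears on the cause of this step. Going by these compounds, whether the same exchange would count on the core with hydrogen on the aromatic nitrogen remains open. So does the effect of an amine or a carboxylic acid on this phenyl ring.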